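A few compounds are considered here, and "the series" means these few. Any claim that something is new, unique, unknown or untested is made for them only; others in the source may bear on it.

Of the compounds shown here, three built on one shared core have been measured in a functional assay on SAOS-2 cells (Homo sapiens) for antiproliferative activity, read by MTT assay, with a stated time of 72 h; a lower number here means a stronger inhibitor, a higher number a weaker inhibitor. Compound 1 `O=C(C1=C(O)C(=O)N(CCCn2ccnc2)C1c1ccc(Br)cc1)c1ccccc1` gives 31600 nM in this assay. Compound 2 `Cc1ccc(NC2=C(C(=O)c3ccccc3)C(c3ccc(Br)cc3)N(CCCn3ccnc3)C2=O)cc1` gives 31900 nM, and compound 3 `CCOc1ccc(NC2=C(C(=O)c3ccccc3)C(c3ccc(Br)cc3)N(CCCn3ccnc3)C2=O)cc1` gives 30900 nM. On these numbers compound 2 sits alongside compound 1 and compound 3: the step of a 1.0-fold higher number from compound 1 to compound 2 (0.00 log units; within the scatter), the step of a 1.0-fold lower number from compound 2 to compound 3 (0.01 log units; within the scatter) and the step of a 1.0-fold lower number from compound 1 to compound 3 (0.01 log units; within the scatter) all lie within the scatter, so the three cannot be told apart.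

Compound 4 `O=C(C1=C(Nc2cccc(Br)c2)C(=O)N(CCCn2ccnc2)C1c1ccc(Br)cc1)c1ccccc1` differs from compound 2 by 3-bromophenyl in place of 4-methylphenyl on an amine nitrogen. For the measured compounds named here, two measured steps bear on this place. Replacing hydroxy with (4-methylphenyl)amino on the double-bonded ring carbon left the number unchanged, as a 1.0-fold higher number from compound 1 to compound 2 (0.00 log units; within the scatter) shows, and exchanging methyl for ethoxy on that aryl ring also left it unchanged, as a 1.0-fold lower number from compound 2 to compound 3 (0.01 log units; within the scatter) shows. Going by the values given here, no measured compound carries a bromine on the aryl ring of the amine, so that part of the change is untested. Given that the two changes at this position produced no step, the step to compound 4 is expected to stay within the scatter, as a 1.0-fold lower number from compound 2 to compound 4 (0.01 log units; within the scatter). Compound 4 is therefore estimated at 31000 nM, with a range from 12000 nM to 80000 nM.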

Compound 4, half-maximal inhibitory concentration: 9090 nM
For compound 4 the middle estimate is 3.4-fold (0.53 log units) above the measured one; measured number outside the range, below it.
By their numbers in this assay, from the lowest: compound 4; then compounds 3, 1 and 2 (each within the scatter of the next).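

In this assay, the amine nitrogen proves not to be a silent place: a 3.5-fold lower number from compound 2 to compound 4 (0.55 log units; beyond the scatter) and a 3.4-fold lower number from compound 3 to compound 4 (0.53 log units; beyond the scatter) show that the aryl ring on this nitrogen can matter, and a 3.5-fold lower number from compound 1 to compound 4 (0.54 log units; beyond the scatter) separates (3-bromophenyl)amino from hydroxy as well. Compound 2 and compound 3 carry an arylamine too, yet neither can be told apart from compound 1, so an aryl ring on this nitrogen does not by itself produce the step; what sets compound 4 apart is the particular ring, 3-bromophenyl. The two rings exchanged between compound 2 and compound 4 have the same count of heavy atoms and no hydrogen-bond donors or acceptors, and no measured evidence is available to explain the step.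

Compound 4 differs from compound 2 both in the substituent and in where it stands on the ring, so (4-bromophenyl)amino and (3-methylphenyl)amino on the same carbon would be needed to separate the two. As far as these compounds go, whether (3-chlorophenyl)amino would give a similar step also remains open.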